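From hydroxymethyl to benzyl on a shared core

The source may report more compounds than this note shows. Statements on the series, on what has been measured and on what is new or still open speak of the compounds shown alone.

Compound 1 `C=CCc1cc(O)c(O)c(CN2CCC(C)CC2)c1` 74.7%
Compound 2 `C=CCc1cc(O)c(O)c(CN2CCC(CCO)CC2)c1` 15.3%
Compound 3 `C=CCc1cc(O)c(O)c(CN2CCC(CO)CC2)c1` 21.9%

In a functional assay on SK-N-SH cells (Homo sapiens) for inhibition, read by MTT assay, with a stated time of 72 h, tested at 30 uM (a higher number here means more inhibition of growth at the concentration tested, a lower number less inhibition of growth), compound 3 gives 21.9%, which sits with compound 2 and far short of compound 1. The measured gaps are a number 6.6 percentage points higher from compound 2 to compound 3 (within the scatter) and a number 52.8 percentage points lower from compound 1 to compound 3 (beyond the scatter).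

Compound 4 `C=CCc1cc(O)c(O)c(CN2CCC(Cc3ccccc3)CC2)c1` carries phenyl in place of hydroxy on a saturated chain carbon bound to a saturated ring carbon, that is, hydroxymethyl to benzyl: phenyl in place of hydroxy on a saturated chain carbon bound to a saturated ring carbon.

For the measured compounds named here, no measured compound carries phenyl. Like compound 1, however, compound 4 has no hydroxy, and the measured loss on introducing a hydroxy-bearing group is large, both a number 52.8 percentage points lower from compound 1 to compound 3 (beyond the scatter) and a number 59.4 percentage points lower from compound 1 to compound 2 (beyond the scatter). A large rise is therefore expected, a number 53.1 percentage points higher from compound 3 to compound 4 (beyond the scatter). Compound 4 is estimated at 75%, with an expected range of 50% to 95%.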

Compound 4, percent growth inhibition at one concentration: 78.8%
For compound 4 the middle estimate is 3.8 percentage points below the measured one; the range from low to high includes it.
By their numbers in this assay, from the lowest: compounds 2 and 3 (each within the scatter of the next); then compounds 1 and 4 (each within the scatter of the next).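

In this assay, the low numbers of the hydroxy-bearing groups do not extend to a much bulkier replacement: benzyl restores growth inhibition from hydroxymethyl (a number 56.9 percentage points higher from compound 3 to compound 4 (beyond the scatter)) and from hydroxyethyl (a number 63.5 percentage points higher from compound 2 to compound 4 (beyond the scatter)). The phenyl-bearing compound and the methyl compound cannot be told apart (a number 4.1 percentage points higher from compound 1 to compound 4 (within the scatter)), so at this place a phenyl in place of hydrogen gives a number in the same range. Nothing available explains these differences. Still open, going by these compounds, is whether an amine or a carboxylic acid here would keep the number high, and whether a hydroxy on the phenyl would bring it down.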